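This account rests on a few compounds, and the source may have more. Where it says the series, first, only, none or still open, it means among the compounds named here.

Among the compounds with values here, compound 3 `O=C1Nc2ccc(-c3cccc(F)c3)cc2/C1=C/c1cc(Cl)c(O)c(Cl)c1` gives -5.8% in an assay on HeLa cells for inhibition of Kinesin-like protein KIF15 (Homo sapiens), read by microscopy, with stated times of 2 s and 20 s, tested at 750 nM (on this read-out lower numbers stand for less inhibition and higher numbers for more inhibition at the one concentration tested (going by the name of the read-out)), the second highest of the three numbers measured so far. Compound 1 `O=C1Nc2ccc(C(=O)N3CCCC3)cc2/C1=C/c1cc(Cl)c(O)c(Cl)c1` gives -10%, and the difference is a number 4.2 percentage points higher from compound 1 to compound 3 (within the scatter). Compound 2 `CN(C)C(=O)c1ccc2c(c1)/C(=C/c1cc(Cl)c(O)c(Cl)c1)C(=O)N2` gives 15.3%; the difference here is a number 21.1 percentage points lower from compound 2 to compound 3 (beyond the scatter). Compound 4 `O=C1Nc2ccc(-c3ccccn3)cc2/C1=C/c1cc(Cl)c(O)c(Cl)c1` has not yet been measured. The change from compound 3 is pyridin-2-yl in place of 3-fluorophenyl on an aromatic carbon. Within the data shown here, no measured step swaps one six-membered aromatic ring for another at this place; the nearest comparison is a number 4.2 percentage points higher from compound 1 to compound 3 (within the scatter), where a ring replaced a carbonyl-bearing group and stayed within the scatter. The step from compound 3 to compound 4 is therefore expected to be a number 3.8 percentage points higher from compound 3 to compound 4 (within the scatter). Compound 4 is estimated at -2%, with a range from -16% to 12%.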

Compound 4, a percentage reported as inhibition, at one concentration (the size of the read-out at that concentration, not a potency): 7.3%
Beside the measured number, compound 4's estimate is 9.3 percentage points below it; the measured number falls inside the stated range.
By their numbers in this assay, from the lowest: compounds 1 and 3 (each within the scatter of the next); then compounds 4 and 2 (each within the scatter of the next).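

Within the data shown here, at this aromatic carbon, the choice of ring counts in this assay: with a number 13.1 percentage points higher from compound 3 to compound 4 (beyond the scatter), exchanging one six-membered aromatic ring for another shifted the number beyond the scatter, something no earlier step had tested. Pyridin-2-yl also separates from the pyrrolidin-1-yl amide, with a number 17.3 percentage points higher from compound 1 to compound 4 (beyond the scatter), but not from dimethylcarbamoyl, with a number 8 percentage points lower from compound 2 to compound 4 (within the scatter). Nothing measured here explains these steps.

The compounds shown leave open whether the place of the ring nitrogen matters, as pyridin-3-yl would show. As far as these compounds go, how an aminomethyl group or a carboxylic acid would read at this carbon also remains unknown.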